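This account rests on a few compounds, and the source may have more. Where it says the series, first, only, none or still open, it means among the compounds named here.

Measured compounds:
compound 1, `Cc1nc(-c2ccc(C(F)(F)F)cc2)sc1CNc1ccc(OCC(=O)O)cc1`, 100%
compound 2, `O=C(O)CSc1ccc(NCc2cccc(Oc3ccccc3)c2)cc1`, 84%

Both compounds were examined in a functional assay on CHO cells for agonist activity at Free fatty acid receptor 1 (Homo sapiens), read by a luciferase reporter; on this read-out lower numbers stand for smaller maximal responses and higher numbers for larger maximal responses. Compound 1 gives 100%, and compound 2 gives 84%. Of the two numbers, compound 2 stands lowest; its nearest neighbour is compound 1, which lies higher by a gap beyond the usual scatter. Among the measured compounds shown here, no pair of measured compounds differs in a single place, so no step can be read directly from these data.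

Compound 3, `CC(C)NC(=O)[C@H]1C[C@@H]1c1ccc(NCc2cccc(Oc3ccccc3)c2)cc1`, has not yet been measured. It differs from compound 2 in one place: 2-(isopropylcarbamoyl)cyclopropyl in place of (carboxymethyl)sulfanyl on an aromatic carbon. The entering group is larger, brings a three-membered ring and two defined stereocentres, and exchanges one hydrogen-bond acceptor for none beyond what is counted. For the measured compounds named here, with no comparable step in hand, the account can only say that a change of this kind at that aromatic carbon is expected to move the maximal response modestly downward, though a result within the scatter of compound 2 remains possible. For compound 3 the estimated step in this assay is a number 14 percentage points lower from compound 2 to compound 3 (beyond the scatter). Compound 3 is therefore expected to reach about 70%, within a range from 40% to 100%.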

Compound 3, largest response reached (reported as percent of maximum), in percent of the reference or control that the assay uses: 62%
For compound 3 the middle estimate is 8 percentage points above the measured one; the range from low to high includes it.
By their numbers in this assay, from the lowest: compound 3; then compound 2; then compound 1.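

In this assay, among the compounds shown here, placing 2-(isopropylcarbamoyl)cyclopropyl instead of (carboxymethyl)sulfanyl on the aromatic carbon para to a large group gives a number 22 percentage points lower from compound 2 to compound 3 (beyond the scatter), the first step in this set that can be read at a single place. The maximal response therefore depends on what this position carries, yet a group with no carboxylic acid, bringing a three-membered ring and two defined stereocentres, still leaves compound 3 at 62%. Nothing measured here speaks to what lies behind this step.

The cyclopropyl ring, the isopropylcarbamoyl group and the two stereocentres enter together, and this single step does not separate their contributions. Still open, going by these compounds, is whether a carboxylic acid or a tetrazole on the cyclopropyl ring, in place of the isopropylcarbamoyl group, would bring the response closer to that of compound 2, and whether the same exchange would give a comparable step on the core of compound 1.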